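Removing the pyridine ester: what happens to hepatocyte stability

The source may hold more compounds than are shown below. What is called first, only, known or untested is meant among the compounds shown, and "the series" means these compounds.

Three compounds share a core and were tested in an ADME assay on cells (Hepatocyte, Homo sapiens) for metabolic stability, with a stated time of 30 min; a higher number here means that more of the compound is left, a lower number that less of the compound is left. Compound 1 `NC1CCC(CN2CCN(c3cc(=O)c4cc(C(F)(F)F)cc([N+](=O)[O-])c4s3)CC2)CC1` carries an amino group on a saturated ring carbon and gives 83.6%. Compound 2 `Nc1cc(C(F)(F)F)cc2c(=O)cc(N3CCN(CC4CCCCC4)CC3)sc12` gives 0.9%. For the measured compounds named here, compound 3 `O=C(OC1CCC(CN2CCN(c3cc(=O)c4cc(C(F)(F)F)cc([N+](=O)[O-])c4s3)CC2)CC1)c1ccncc1`, in which a ((pyridin-4-yl)carbonyl)oxy group sits on the saturated ring carbon, gives 1%; its number lies within the scatter of compound 2 and far under compound 1, so only a single measured step separates it from the stable end of the set: a number 82.6 percentage points lower from compound 1 to compound 3 (beyond the scatter).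

Going by the values given here, compound 4 `O=c1cc(N2CCN(CC3CCCCC3)CC2)sc2c([N+](=O)[O-])cc(C(F)(F)F)cc12` is the next compound. hydrogen in place of ((pyridin-4-yl)carbonyl)oxy on a saturated ring carbon The one step that bears on this change is the large fall from compound 1 to compound 3, but it swapped an amino group for the ester, whereas here the ester is simply replaced by hydrogen and no amino group returns. Compound 2, which also lacks any group at that position, sits at the low end. On this basis compound 4 is expected to stay low, with an estimated step of a number 7 percentage points higher from compound 3 to compound 4 (within the scatter). The estimate for compound 4 in this assay is 8%, expected to fall between 0.5% and 45%.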

Compound 4, percent of the compound remaining: 82.4%
For compound 4 the middle estimate is 74.4 percentage points below the measured one; measured number above the stated range.
By their numbers in this assay, from the lowest: compounds 2 and 3 (each within the scatter of the next); then compounds 4 and 1 (each within the scatter of the next).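

Replacing ((pyridin-4-yl)carbonyl)oxy with hydrogen on the saturated ring carbon gives a number 81.4 percentage points higher from compound 3 to compound 4 (beyond the scatter) in this assay, so the low number of compound 3 goes with the ester and not with the rest of its structure. At that same ring carbon, hydrogen in place of amino gives a number 1.2 percentage points lower from compound 1 to compound 4 (within the scatter), so among these compounds amino and hydrogen cannot be told apart there and only the ester stands out. The other change lies on an aromatic carbon, where nitro in place of amino gives a number 81.5 percentage points higher from compound 2 to compound 4 (beyond the scatter), which ties the low number of compound 2 to that aromatic amino group and not to the unsubstituted saturated ring it shares with compound 4.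

Why the ester and the aromatic amino group go with so little compound left remains unexplained, as no measurement here speaks to a cause. From the compounds shown here alone, it also remains open whether a hydroxyl group or a simple acetate ester on the saturated ring carbon, or a nitrile on the aromatic carbon, would give a high or a low number.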